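The source may report more compounds than this note shows. Statements on the series, on what has been measured and on what is new or still open speak of the compounds shown alone.

Working notes on the series. Compound 1 `Cn1c(/C=C/C(=O)c2ccc(O)cc2O)cc(Br)c1Br` gives 180 nM in a functional assay on WRL68 cells (Homo sapiens) for cytotoxicity, read by MTT assay, with stated times of 6 h and 48 h; on this read-out lower numbers stand for stronger inhibition and higher numbers for weaker inhibition. Compound 2 `Cn1c(/C=C/C(=O)c2ccc(O)cc2)cc(Br)c1Br` gives 1910 nM in this assay. The change between these two is hydrogen in place of hydroxy on an aromatic carbon, and the step that it made is an 11-fold higher number from compound 1 to compound 2 (1.03 log units; beyond the scatter). Compound 3 `O=C(/C=C/c1cc(Br)c(Br)[nH]1)c1ccccc1O` gives 1420 nM in this assay, and this value and that of compound 2 lie within the scatter of each other. The difference between the core of compound 3 and the core of compound 1 is not broken down here.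

Compound 4 `O=C(/C=C/c1cc(Br)c(Br)[nH]1)c1ccccc1` has not yet been measured in this assay. The change from compound 3 to compound 4 is hydrogen in place of hydroxy on an aromatic carbon. For the measured compounds named here, it is the same kind of change as the one seen between compound 1 and compound 2, but the place differs: in compound 1 the place is also meta to a hydroxy group, whereas in compound 3 it is not. Because of an 11-fold higher number from compound 1 to compound 2 (1.03 log units; beyond the scatter), compound 4 is expected to give a higher number than compound 3, with an estimated step of a 7.7-fold higher number from compound 3 to compound 4 (0.89 log units; beyond the scatter). The estimate for compound 4 is 11000 nM, expected to fall between 3000 nM and 40000 nM.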

Compound 4, half-maximal inhibitory concentration: >= 100000 nM
Compound 4 was reported as a limit; the forecaster's own chance of this, stated with the estimate: 15%; at least 9.0-fold (0.95 log units) between middle value and limit.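

Hydrogen in place of hydroxy on an aromatic carbon gives a higher number on both cores in this assay, so the direction of the change carries over from one core to the other, but its size does not: the same change on two cores in this assay, an 11-fold higher number (1.03 log units; beyond the scatter) from compound 1 to compound 2 and an at least 70-fold higher number (1.84 log units; beyond the scatter) from compound 3 to compound 4, at least 6.6-fold (0.82 log units) apart, beyond the scatter of two such steps

On the core of compound 3, the change gives an at least 70-fold higher number from compound 3 to compound 4 (1.84 log units; beyond the scatter), and this figure marks only a lower bound on the step, not its actual size. Compound 4 gives >= 100000 nM, which is a limit of the assay and not a number, so the full gap between the two steps cannot be read: the limit of >= 100000 nM in this assay, at which 1 of the 4 values shown sits.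

No pair shown isolates which difference between the core of compound 1 and the core of compound 3 sets the size of the step. Also open, from the compounds shown here alone, is whether another group on that aromatic carbon, such as an amine or a methoxy group, would keep the number close to that of compound 3.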